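A Fluorine-for-Methyl Swap on a Weakly Cytotoxic Amide

The source may report more compounds than this note shows. Statements on the series, on what has been measured and on what is new or still open speak of the compounds shown alone.

Within the data shown here, compound 1 `Cc1ccc(NC(=O)CN2CCN(c3nnc(Cc4ccncc4)c4ccccc34)CC2)c(C)c1` is the only member of this small set with a reported number. In a functional assay on A549 cells (Homo sapiens) for cytotoxicity, read by MTT assay, with a stated time of 72 h (on this read-out higher numbers stand for weaker inhibition and lower numbers for stronger inhibition), compound 1 gives 45000 nM, a weak result. A related compound 2 `COc1ccc(NC(=O)CN2CCN(c3nnc(Cc4ccccc4)c4ccccc34)CC2)cc1OC`, which carries a different aryl amide group, is recorded in this assay as "not active" (no number reported), with no number at all, so compound 1 stands as the sole quantitative reference point here.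

Compound 3 `Cc1ccc(F)cc1NC(=O)CN1CCN(c2nnc(Cc3ccncc3)c3ccccc23)CC1` has not yet been tested. It differs from compound 1 in one place: 5-fluoro-2-methylphenyl in place of 2,4-dimethylphenyl on an amide-type nitrogen. Among the measured compounds shown here, two similarly sized aryl groups with no hydrogen-bond donors or acceptors are exchanged, and no measured pair shows what such an exchange does. The step from compound 1 to compound 3 in this assay is expected to be small, a 1.1-fold higher number from compound 1 to compound 3 (0.05 log units; within the scatter), no larger than the scatter of repeat measurements. Compound 3 is therefore estimated at 50000 nM in this assay, within a range from 20000 nM to 150000 nM.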

Compound 3, half-maximal inhibitory concentration: 38900 nM
The estimate for compound 3 lay 1.3-fold (0.11 log units) above the measured number; low and high end bracket the measured number.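

In this assay, exchanging 2,4-dimethylphenyl for 5-fluoro-2-methylphenyl on the amide-type nitrogen gives a 1.2-fold lower number from compound 1 to compound 3 (0.06 log units; within the scatter), so this read-out cannot tell the two compounds apart. This is the only measured pair shown for this position, and it establishes that, in these cells, one of the two aryl groups can take the other's place without a change that stands out from repeat measurements. No available information bears on why the two numbers agree.

The pair leaves open whether this position responds to any change at all, since both aryl groups have the same heavy-atom count and neither carries a hydrogen-bond donor or acceptor. An aryl group carrying an amine or a carboxylic acid, or a longer chain on the amide-type nitrogen in place of the aryl group, could test that question.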